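This account rests on a few compounds, and the source may have more. Where it says the series, first, only, none or still open, it means among the compounds named here.

In a functional assay on SK-OV-3 cells (Homo sapiens) for inhibition, read by CCK-8 assay, with a stated time of 70 h (a higher number here means a weaker inhibitor, a lower number a stronger inhibitor), compound 1 `COC(=O)c1ccc(COc2ccc(OCCOCCNC3CCCC3)cc2)cc1` gives 6990 nM. Compound 2 `O=C(O)c1ccc(COc2ccc(OCCOCCNC3CCCC3)cc2)cc1` gives > 100000 nM, which is a limit of the assay and not a number. Compound 2 therefore has no exact position and stands at the limit of > 100000 nM in this assay, at which 1 of the 2 values shown sits.

Compound 3 `O=[N+]([O-])c1cccc(COc2ccc(OCCOCCNC3CCCC3)cc2)c1` differs from compound 2 as follows: 3-nitrophenyl in place of 4-carboxyphenyl on a saturated chain carbon bound to an oxygen on an aromatic ring. In words, this is 3-nitrophenyl in place of 4-carboxyphenyl on a saturated chain carbon bound to an oxygen on an aromatic ring.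

Within the data shown here, the only measured step bearing on this change is an at least 14-fold higher number from compound 1 to compound 2 (1.15 log units; beyond the scatter), a large step from the methyl ester to the free acid. Compound 3 has no free acid, and neither does compound 1, which gives 6990 nM. A large step to a lower number in this assay is therefore expected, back towards the level of compound 1. Among the measured compounds shown here, the series holds no measured example of the 3-nitrophenyl group, so the range stays wide. The expected move is an at least 14-fold lower number from compound 2 to compound 3 (1.15 log units; beyond the scatter). Compound 3 is estimated at 7000 nM, with an expected range of 2200 nM to 25000 nM.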

Compound 3, half-maximal inhibitory concentration: 15400 nM
For compound 3 the middle estimate is 2.2-fold (0.34 log units) below the measured one, within the range that was stated.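

In this assay, the change at the saturated chain carbon bound to an oxygen on an aromatic ring gives an at least 6.4-fold lower number from compound 2 to compound 3 (0.81 log units; beyond the scatter), so a ring group without the free acid can carry a measurable value at this place. Compound 2 stands at a limit of the assay and not at a number, so that step gives only a minimum size: the limit of > 100000 nM in this assay, at which 1 of the 3 values shown sits. The comparison with the ester gives a 2.2-fold higher number from compound 1 to compound 3 (0.34 log units; beyond the scatter), so a measurable value in this assay at this place does not depend on the 4-(methoxycarbonyl)phenyl group, although the 3-nitrophenyl group gives the higher number of the two.

The compounds shown do not separate the identity of the ring group from its numbering on the ring, since the 3-nitrophenyl group differs from the 4-carboxyphenyl and 4-(methoxycarbonyl)phenyl groups in both; a 4-nitrophenyl or a 3-carboxyphenyl group would address this. As far as these compounds go, it also remains open whether a nitrile or an amide on the same ring would give a number closer to that of the ester or to that of the nitro compound.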